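The source may report more compounds than this note shows. Statements on the series, on what has been measured and on what is new or still open speak of the compounds shown alone.

Measured compounds in a functional assay on MCF7 cells (Homo sapiens) for inhibition; on this read-out higher numbers stand for weaker inhibition and lower numbers for stronger inhibition:
- compound 1 `CC/C(=C(/c1ccc(/C=C/C(=O)O)cc1)c1cc2ccccc2[nH]1)c1ccccc1C#N` gives 9 nM
- compound 2 `CC/C(=C(/c1ccc(/C=C/C(=O)O)cc1)c1cc2ccccc2[nH]1)c1ccc(C#N)cc1` gives 278 nM
- compound 3 `CC/C(=C(/c1ccc(/C=C/C(=O)O)cc1)c1cc2ccccc2[nH]1)c1cccc(F)c1C#N` gives 40 nM

Compound 1 gives the lowest number of the three in this assay; its nearest neighbour is compound 3 at a 4.4-fold higher number from compound 1 to compound 3 (0.65 log units; beyond the scatter), and compound 2 lies furthest at a 31-fold higher number from compound 1 to compound 2 (1.49 log units; beyond the scatter).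

The unmeasured compound 4 `CC/C(=C(/c1ccc(/C=C/C(=O)O)cc1)c1cc2ccccc2[nH]1)c1ccc(C#N)cc1Cl` differs from compound 1 in one place: 2-chloro-4-cyanophenyl in place of 2-cyanophenyl on a double-bonded chain carbon bound to a double-bonded chain carbon and a saturated chain carbon.

For the measured compounds named here, two measured steps bear on this change. Moving the nitrile from the 2-cyanophenyl to the 4-cyanophenyl arrangement gave a 31-fold higher number from compound 1 to compound 2 (1.49 log units; beyond the scatter), a large rise in the number. Adding a halogen to the ring, fluoro in place of hydrogen, gave a 4.4-fold higher number from compound 1 to compound 3 (0.65 log units; beyond the scatter), a modest rise. The third step, a 7.0-fold lower number from compound 2 to compound 3 (0.84 log units; beyond the scatter), combines both kinds of change and runs the other way. Going by the values given here, no measured pair shows chloro on a 4-cyanophenyl, so the chloro contribution is unknown here; the nitrile relocation is expected to dominate.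

For compound 4 in this assay a step of a 33-fold higher number from compound 1 to compound 4 (1.52 log units; beyond the scatter) is therefore expected, a clear weakening relative to compound 1. Compound 4 is estimated at 300 nM, with a range of 80 nM to 1200 nM, taking compound 2 at 278 nM as the main anchor and allowing the chloro to shift the number in either direction.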

Compound 4, half-maximal inhibitory concentration: 49 nM
Estimate against measurement, compound 4: 6.1-fold (0.79 log units) above; measured number below the stated range.
By their numbers in this assay, from the lowest: compound 1; then compounds 3 and 4 (each within the scatter of the next); then compound 2.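

In this assay, chloro in place of hydrogen on the 4-cyanophenyl gives a 5.7-fold lower number from compound 2 to compound 4 (0.75 log units; beyond the scatter), so much of the large penalty seen with compound 2 is not fixed by the nitrile arrangement alone and can be offset by a second substituent on that ring. The 2-chloro-4-cyanophenyl group still gives a 5.4-fold higher number from compound 1 to compound 4 (0.74 log units; beyond the scatter), so it does not match the plain 2-cyanophenyl, while a 1.2-fold higher number from compound 3 to compound 4 (0.09 log units; within the scatter) leaves it level with the 2-cyano-3-fluorophenyl group, and two differently substituted rings at this place on the double-bonded chain carbon thus read alike. The compounds shown carry no measured evidence on why chloro has this effect.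

On these data alone, whether the offset is particular to chloro stays open, since a methyl, a bromo or a methoxy on the same aromatic carbon of the 4-cyanophenyl could give a smaller or larger step. Also open, as far as these compounds go, is what chloro does on the 2-cyanophenyl of compound 1, which would show whether that substituent can improve on the best ring here or only repairs the weaker 4-cyanophenyl arrangement.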